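Compound 2 to compound 3: an aromatic swap on the amide

A few compounds are considered here, and "the series" means these few. Any claim that something is new, unique, unknown or untested is made for them only; others in the source may bear on it.

Values in an ADME assay on HEp-2 cells (Homo sapiens) for cytotoxicity; on this read-out higher numbers stand for lower toxicity in this test and lower numbers for higher toxicity in this test:
- compound 1 `Cc1ccc(NC(=O)CNS(=O)(=O)c2cccc3cccnc23)c(C)c1`: > 50000 nM
- compound 2 `Cc1ccnc(C)c1NC(=O)[C@@H]1CCCN1S(=O)(=O)c1cccc2cccnc12`: > 50000 nM

Compound 2 gives > 50000 nM, a limit of the assay and not a number. It shares with compound 1 (the limit of > 50000 nM in this assay, at which 2 of the 2 values shown sit). Compound 3 `Cc1ccc(Cl)c(NC(=O)[C@@H]2CCCN2S(=O)(=O)c2cccc3cccnc23)c1` carries 2-chloro-5-methylphenyl in place of 2,4-dimethylpyridin-3-yl on an amide-type nitrogen. Among the measured compounds shown here, no measured step exists to size this change. Compound 1, whose amide nitrogen also carries an aromatic ring of carbon only, gives > 50000 nM, again a limit. The expected step of an at least 1.1-fold lower number from compound 2 to compound 3 (0.04 log units; that floor lies within the scatter) is none beyond the scatter. The estimate for compound 3 is 45000 nM, with an expected range of 15000 nM to 80000 nM.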

Compound 3, half-maximal cytotoxic concentration: > 50000 nM
Compound 3 gave a limit, no number; the forecaster's own chance of this, stated with the estimate: 65%; at least 1.1-fold (0.04 log units) between middle value and limit.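

No step can be read from compound 2 to compound 3, as both give a limit of the assay and not a number: the limit of > 50000 nM in this assay, at which 3 of the 3 values shown sit.

The compounds shown leave open whether 2-chloro-5-methylphenyl in place of 2,4-dimethylpyridin-3-yl changes the read-out at all.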